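The source may hold more compounds than are shown below. What is called first, only, known or untested is meant among the compounds shown, and "the series" means these compounds.

Compound 2 `COc1cc(-c2ccnc3cc(-c4ccc(C)c(C)c4)nn23)cc(OC)c1OC` and compound 1 `Cn1ccc2cc(-c3cc4nccc(-c5ccc(F)cc5)n4n3)ccc21` are the two members of this series that have been measured. In a functional assay on B16-F0 cells (Mus musculus) for inhibition, read by CCK-8 assay, with a stated time of 48 h (on this read-out lower numbers stand for stronger inhibition and higher numbers for weaker inhibition), compound 2 gives 391 nM, the lower of the two numbers, while compound 1 gives 4780 nM; the gap between them lies beyond the usual scatter of repeated measurements, so compound 2 is the stronger inhibitor of the pair. Compound 3 `COc1cc(-c2ccnc3cc(-c4ccc5ccn(C)c5c4)nn23)cc(OC)c1OC` has not yet been measured. It differs from compound 2 in a single place: 1-methyl-1H-indol-6-yl in place of 3,4-dimethylphenyl on an aromatic carbon. Among the compounds with values here, no measured pair of compounds shows exactly this exchange, so its effect is not known from the data at hand. The step is expected to be modest, with a 1.7-fold higher number from compound 2 to compound 3 (0.22 log units; within the scatter) most likely staying close to the scatter, a slight weakening being somewhat more probable than a gain. In this assay compound 3 is therefore estimated at 650 nM, with a range from 200 nM to 2500 nM.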

Compound 3, half-maximal inhibitory concentration: 657 nM
Compound 3: the middle estimate sits 1.0-fold (0.00 log units) below what was measured; the measured number falls inside the stated range.
By their numbers in this assay, from the lowest: compounds 2 and 3 (each within the scatter of the next); then compound 1.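

In this assay the exchange of 3,4-dimethylphenyl for 1-methyl-1H-indol-6-yl gives a 1.7-fold higher number from compound 2 to compound 3 (0.23 log units; within the scatter) and leaves the two compounds indistinguishable. With the rest of the molecule unchanged, this aromatic carbon of the five-membered aromatic ring with 2 nitrogen therefore tolerates a larger group of two fused aromatic rings, one with a ring nitrogen, as well as a single six-membered aromatic ring of carbon only. No measurement at hand explains why the two groups give such similar numbers. Going by these compounds, whether a morpholine or a carboxylic acid in the same place would hold up equally well remains open. It is also unclear whether the methyl on the indole nitrogen matters, since an indole with a free hydrogen on that nitrogen does not appear among these compounds.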